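Methyl for Chloro on the Sulfonyl Aryl Ring

The source may report more compounds than this note shows. Statements on the series, on what has been measured and on what is new or still open speak of the compounds shown alone.

Measured compounds:
- compound 1, `CCOC(=O)c1nn(-c2ccccc2)c(-c2ccc(OC)cc2OC)c1C`: 5.77%
- compound 2, `COc1ccc(C2=NN(C(=O)NS(=O)(=O)c3ccc(Cl)cc3)CC2c2ccccc2)c(OC)c1`: 23.6%
- compound 3, `COc1ccc(C2=NN(C(=O)NS(=O)(=O)c3ccc(Cl)cc3)CC2C)c(OC)c1`: 18.8%

In a functional assay on the whole organism (strain albino) for inhibition, with Rattus norvegicus as the target, read by paw edema, with stated times of 30 min and 4 h, at a dose of 25 mg/kg by the intraperitoneal route (on this read-out lower numbers stand for less inhibition and higher numbers for more inhibition at the one dose given (going by the name of the read-out)), compound 2 stands highest of the three numbers. Its nearest neighbour is compound 3, and the step of a number 4.8 percentage points lower from compound 2 to compound 3 (within the scatter) stays within the scatter. Compound 1, built on a different core, lies furthest away, and its value against that of compound 2 is a gap beyond the scatter.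

Compound 4, `COc1ccc(C2=NN(C(=O)NS(=O)(=O)c3ccc(C)cc3)CC2c2ccccc2)c(OC)c1`, keeps the whole frame of compound 2 and differs from it in one place: methyl in place of chloro on an aromatic carbon.

Among the measured compounds shown here, only one measured step, from compound 2 to compound 3, is known for this frame, and it alters a saturated ring carbon, not the sulfonyl-bearing aryl ring, so it speaks to the change in compound 4 only as a sign that, for this frame, a small swap left the number level within the scatter. For the measured compounds named here, no measured pair exchanges chloro for methyl anywhere. The expectation for this assay is therefore a step of no size beyond the scatter, in no assured direction.

Compound 4 is expected to give about 22%, with a range from 12% to 32%. The step this estimate means, a number 1.6 percentage points lower from compound 2 to compound 4 (within the scatter), is expected to remain within the scatter.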

Compound 4, a percentage reported as inhibition, in the whole organism at one dose (the size of the read-out at that dose, not a potency): 7.21%
Beside the measured number, compound 4's estimate is 14.8 percentage points above it; measured number below the stated range.
By their numbers in this assay, from the lowest: compounds 1 and 4 (each within the scatter of the next); then compounds 3 and 2 (each within the scatter of the next).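

In this assay, the group on the sulfonyl-bearing aryl ring, para to a large group, turns out to matter on this frame: methyl in place of chloro gives a number 16.4 percentage points lower from compound 2 to compound 4 (beyond the scatter). Among the compounds shown here, the earlier compounds could not show this, since their only step within the frame, a number 4.8 percentage points lower from compound 2 to compound 3 (within the scatter), changes a saturated ring carbon and stays within the scatter, whereas this exchange of one heavy atom for another, with no change in the counted hydrogen-bond donors or acceptors, goes beyond it. Nothing available here explains why this exchange lowers the number.

The compounds shown leave open how other groups at this place, such as bromo, methoxy or an amine, would stand against chloro and methyl, and so whether chloro is unusual here or methyl is. They also leave open whether the same exchange would take a similar step on the frame of compound 3, which carries methyl in place of phenyl on the saturated ring carbon.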